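The compounds below may be only part of what the source reports. "The series", "measured", "known", "first", "only" and "open" are said of these compounds alone.

Three compounds share one core and differ only in the aryl group on the amide nitrogen. In an in vitro assay on Sf21 cells for inhibition of high affinity 3',5'-cyclic-AMP phosphodiesterase 7A (Homo sapiens), read by scintillation proximity assay, with a stated time of 30 min (on this read-out higher numbers stand for weaker inhibition and lower numbers for stronger inhibition), compound 1 `CC(=O)Nc1ccc(NC(=O)c2cn(Cc3c(F)cccc3F)c3ccc(=O)[nH]c3c2=O)cc1` gives 24 nM, compound 2 `O=C(Nc1ccccc1)c1cn(Cc2c(F)cccc2F)c2ccc(=O)[nH]c2c1=O` gives 94 nM, and compound 3 `N#Cc1cccc(NC(=O)c2cn(Cc3c(F)cccc3F)c3ccc(=O)[nH]c3c2=O)c1` gives 1070 nM. Compound 3 therefore has the highest number of the three; the steps that reach it are an 11-fold higher number from compound 2 to compound 3 (1.06 log units; beyond the scatter) and a 45-fold higher number from compound 1 to compound 3 (1.65 log units; beyond the scatter), both beyond the scatter. Compound 4 `COc1cc(NC(=O)c2cn(Cc3c(F)cccc3F)c3ccc(=O)[nH]c3c2=O)cc(OC)c1` differs from compound 3 in one place: 3,5-dimethoxyphenyl in place of 3-cyanophenyl on an amide-type nitrogen. For the measured compounds named here, two measured steps bear on this change. The step of an 11-fold higher number from compound 2 to compound 3 (1.06 log units; beyond the scatter) shows what the cyano group adds to the number, so taking it away is expected to bring the number back toward that of compound 2. Going by the values given here, the step of a 3.9-fold higher number from compound 1 to compound 2 (0.59 log units; beyond the scatter) shows that a substituent carrying a hydrogen-bond acceptor gave a lower number than bare phenyl in this assay, though no measured compound carries methoxy groups, so their own effect is unknown. The step from compound 3 to compound 4 is thus expected to be a 7.1-fold lower number from compound 3 to compound 4 (0.85 log units; beyond the scatter), a clear move to a lower number. Compound 4 is estimated at 150 nM, with a range from 40 nM to 600 nM.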

Compound 4, half-maximal inhibitory concentration: 212 nM
Compound 4: middle estimate off by 1.4-fold (0.15 log units), on the low side, and the stated range covers the measured number.
By their numbers in this assay, from the lowest: compound 1; then compound 2; then compound 4; then compound 3.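

Replacing 3-cyanophenyl with 3,5-dimethoxyphenyl on the amide-type nitrogen gives a 5.0-fold lower number from compound 3 to compound 4 (0.70 log units; beyond the scatter) and so recovers much of the ground lost with the nitrile, which shows that this position tolerates a larger substituted phenyl group better than compound 3 alone would suggest. Yet the two methoxy groups do not match the simpler groups, since replacing bare phenyl with 3,5-dimethoxyphenyl gives a 2.3-fold higher number from compound 2 to compound 4 (0.35 log units; beyond the scatter) and replacing 4-acetamidophenyl with it gives an 8.8-fold higher number from compound 1 to compound 4 (0.95 log units; beyond the scatter) as the acetamido compound keeps the lowest number. Nothing measured here gives a reason for these differences. Still open, from the compounds shown here alone, is whether one methoxy group alone would give a number closer to that of bare phenyl. Also open, going by these compounds, is how an amine, a carboxylic acid or a longer alkoxy chain on the phenyl ring would compare.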